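The compounds below may be only part of what the source reports. "The series", "measured", "known", "first", "only" and "open" are said of these compounds alone.

Compound 1 `CCn1c(C(=O)NCCC(=O)OC)ccc1C(CC)(CC)c1ccc(OCS(=O)(=O)c2ccccc2)c(C)c1` is the weakest of the three compounds measured here: in a functional assay on PC-3 cells (Homo sapiens) for antiproliferative activity, read by MTT assay, with a stated time of 24 h (a higher number here means a weaker inhibitor, a lower number a stronger inhibitor), compound 1 gives 40400 nM, the highest number of the set. Compound 2 `CCn1c(C(=O)N[C@@H](CO)C(C)C)ccc1C(CC)(CC)c1ccc(OCS(=O)(=O)c2ccccc2)c(C)c1` gives 10600 nM and compound 3 `CCn1c(C(=O)N[C@@H](CO)CCO)ccc1C(CC)(CC)c1ccc(OCS(=O)(=O)c2ccccc2)c(C)c1` gives 14100 nM in this assay. Both steps away from compound 1 lower the number: a 3.8-fold lower number from compound 1 to compound 2 (0.58 log units; beyond the scatter) and a 2.9-fold lower number from compound 1 to compound 3 (0.46 log units; beyond the scatter). Compound 4 `CCn1c(C(=O)N[C@@H](C(=O)O)C(C)C)ccc1C(CC)(CC)c1ccc(OCS(=O)(=O)c2ccccc2)c(C)c1` differs from compound 1 in the same place as those two steps: 1-carboxy-2-methylpropyl in place of 2-(methoxycarbonyl)ethyl on an amide-type nitrogen. Since both measured replacements on the amide-type nitrogen gave modest lowerings, a modest lowering is expected here as well, a 2.7-fold lower number from compound 1 to compound 4 (0.43 log units; beyond the scatter). Compound 4 is therefore estimated to give 15000 nM in this assay, with a range from 5000 nM to 45000 nM.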

Compound 4, half-maximal inhibitory concentration: 3070 nM
The estimate for compound 4 lay 4.9-fold (0.69 log units) above the measured number; measured number below the stated range.
By their numbers in this assay, from the lowest: compound 4; then compounds 2 and 3 (each within the scatter of the next); then compound 1.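

In this assay the group on the amide-type nitrogen proves able to produce a large step, not only the modest ones seen before, with 1-carboxy-2-methylpropyl replacing 2-(methoxycarbonyl)ethyl (a 13-fold lower number from compound 1 to compound 4 (1.12 log units; beyond the scatter)). The carboxy compound also stands apart from both hydroxyl-bearing compounds (a 4.6-fold lower number from compound 3 to compound 4 (0.66 log units; beyond the scatter); a 3.5-fold lower number from compound 2 to compound 4 (0.54 log units; beyond the scatter)), and the last step shows that carboxy in place of hydroxymethyl on one chain carbon is enough to move the number beyond the scatter. No measurement given here accounts for this gain. Still open, going by these compounds, is whether an amine or a primary carboxamide in place of carboxy would keep it, and whether a longer chain on that carbon would.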